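The source may hold more compounds than are shown below. What is called first, only, known or untested is meant among the compounds shown, and "the series" means these compounds.

Measured in a functional assay on MDA-MB-231 cells (Homo sapiens) for antiproliferative activity, read by sulforhodamine B assay, with a stated time of 48 h; on this read-out lower numbers stand for stronger inhibition and higher numbers for weaker inhibition:
Compound 1 `COc1cc(OC)c2sc(-c3ccc(N/C=C\C(=O)c4cc(OC)c(OC)c([N+](=O)[O-])c4)c(C)c3)nc2c1`: 7400 nM
Compound 2 `COc1cc(OC)c2sc(-c3ccc(N/C=C\C(=O)c4cc(OC)c(OC)c(OC)c4)cc3)nc2c1`: 15800 nM
Compound 3 `COc1cc(C(=O)/C=C\Nc2ccc(-c3nc4cc(OC)c(OC)c(OC)c4s3)cc2)cc([N+](=O)[O-])c1OC`: 9800 nM

In this assay, compound 3 gives 9800 nM. This is the middle one of the three numbers, and it lies within the scatter of the values of both compound 1 and compound 2. The next compound to be considered is compound 4 `COc1cc(OC)c2sc(-c3ccc(N/C=C\C(=O)c4cc(OC)c(OC)c([N+](=O)[O-])c4)cc3)nc2c1`, which has not yet been measured. It departs from compound 3 by a single change on the shared core: hydrogen in place of methoxy on an aromatic carbon. Going by the values given here, no measured pair isolates this change, so the data give no direct size for it. The core of compound 1 carries the same two methoxy groups as that of compound 4, and compound 1 gives 7400 nM, within the scatter of compound 3. No step beyond the scatter is therefore expected in this assay, and no direction is favoured. The expected change is a 1.1-fold lower number from compound 3 to compound 4 (0.04 log units; within the scatter). For compound 4 the estimated value is 9000 nM, with an expected range from 4500 nM to 18000 nM.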

Compound 4, half-maximal inhibitory concentration: 3060 nM
Estimate against measurement, compound 4: 2.9-fold (0.47 log units) above; the measured number lies below the stated range.
By their numbers in this assay, from the lowest: compound 4; then compounds 1, 3 and 2 (each within the scatter of the next, the first and the last beyond it).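

In this assay, going by these compounds alone, hydrogen in place of methoxy on an aromatic carbon of the shared core gives a 3.2-fold lower number from compound 3 to compound 4 (0.51 log units; beyond the scatter), so this position, which no earlier pair isolated, does affect the read-out. Two further single changes also lead to compound 4: nitro in place of methoxy on an aromatic carbon gives a 5.2-fold lower number from compound 2 to compound 4 (0.71 log units; beyond the scatter), and removing a methyl group gives a 2.4-fold lower number from compound 1 to compound 4 (0.38 log units; beyond the scatter), which makes compound 4 the strongest of the four in this assay. No other data bear on why these steps arise.

Going by these compounds, how a hydroxyl group, a fluorine atom or an amine at the methoxy position would compare with hydrogen stays open. On these data alone, each change also rests on a single pair, so whether its step holds on other compounds is unknown.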